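The source may report more compounds than this note shows. Statements on the series, on what has been measured and on what is new or still open speak of the compounds shown alone.

Compound 1 `O=C(Nc1cccc(F)c1)c1cc(=O)[nH]c2cc(-c3ccc(F)cc3)ccc12`: 10300 nM
Compound 2 `O=C(Nc1cccc(F)c1)c1cc(=O)[nH]c2cc(-c3cccnc3F)ccc12`: 11600 nM

In a functional assay on KYSE-410 cells (Homo sapiens) for antiproliferative activity, read by MTT assay, with a stated time of 72 h (a lower number here means a stronger inhibitor, a higher number a weaker inhibitor), compound 2 gives 11600 nM. That places it within the scatter of compound 1, which gives 10300 nM. Compound 3 `C#Cc1ccc2c(C(=O)Nc3cccc(F)c3)cc(=O)[nH]c2c1` departs from compound 2 with ethynyl in place of 2-fluoropyridin-3-yl on an aromatic carbon. For the measured compounds named here, only one measured step bears on this site: a 1.1-fold higher number from compound 1 to compound 2 (0.05 log units; within the scatter). That step exchanged one ring-bearing group for another and stayed within the scatter. Going by the values given here, no measured compound here lacks a ring at this place, so the data offer no direct guide to the loss of the ring. No firm direction can therefore be expected in this assay, and only a small shift is anticipated, though with wide uncertainty. The expected size is an estimated 1.3-fold lower number from compound 2 to compound 3 (0.11 log units; within the scatter). Compound 3 is estimated at 9000 nM, with an expected range of 3000 nM to 27000 nM.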

Compound 3, half-maximal inhibitory concentration: 9700 nM
Beside the measured number, compound 3's estimate is 1.1-fold (0.03 log units) below it, within the range that was stated.
By their numbers in this assay, from the lowest: compounds 3, 1 and 2 (each within the scatter of the next).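

In this assay, ethynyl in place of 2-fluoropyridin-3-yl gives a 1.2-fold lower number from compound 2 to compound 3 (0.08 log units; within the scatter), and ethynyl in place of 4-fluorophenyl gives a 1.1-fold lower number from compound 1 to compound 3 (0.03 log units; within the scatter). The earlier step only exchanged one ring-bearing group for another, whereas these two steps show that, across these three compounds, a group with no ring at this place leaves the number within the scatter, so a ring here is not required to hold it there. Nothing available explains this result.

As far as these compounds go, all three compounds lie within the scatter of one another, so it remains open whether any group at this place can move the number beyond it. From the compounds shown here alone, what an amine, a carboxylic acid or a longer chain on this aromatic carbon would do also remains open.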